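A few compounds are considered here, and "the series" means these few. Any claim that something is new, unique, unknown or untested is made for them only; others in the source may bear on it.

Three compounds have been measured:
compound 1, `COc1ccccc1OCC(O)CNCC(=O)Nc1ccc(C2=NNC(=O)CC2)cc1`, 4.6 umol/kg
compound 2, `COc1ccccc1OCC(O)CNCC(=O)Nc1ccc(C2=NNC(=O)CC2C)cc1`, 3 umol/kg
compound 3, `COc1ccccc1OCC(O)CNCCC(=O)Nc1ccc(C2=NNC(=O)CC2)cc1`, 4.3 umol/kg

The read-out throughout is a functional assay on the whole organism with Rattus norvegicus as the target; on this read-out lower numbers stand for an effect already at smaller amounts and higher numbers for an effect only at larger amounts of compound. Compounds 1 and 2 share a core and differ in one place: methyl in place of hydrogen on a saturated ring carbon. The step that this made was a 1.5-fold lower number from compound 1 to compound 2 (0.19 log units; within the scatter), so the two values cannot be told apart. Compound 3 carries a different core; how the core of compound 3 differs from that of compound 1 is not broken down here. In this assay compound 3 gives 4.3 umol/kg, a number that sits within the scatter of compound 1 and of compound 2, so no order can be read among the three. Compound 4, `COc1ccccc1OCC(O)CNCCC(=O)Nc1ccc(C2=NNC(=O)CC2C)cc1`, is not yet measured. It stands to compound 3 as compound 2 stands to compound 1: methyl in place of hydrogen on a saturated ring carbon, the same change at the same place. Since the change gave a 1.5-fold lower number from compound 1 to compound 2 (0.19 log units; within the scatter), a step of the same small size is expected from compound 3 to compound 4: a 1.5-fold lower number from compound 3 to compound 4 (0.17 log units; within the scatter). This rests on a single earlier pair, so the expectation is loose. For compound 4 the estimate in this assay is 2.9 umol/kg, with a likely range from 1.5 umol/kg to 5.5 umol/kg.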

Compound 4, dose for half-maximal effect: 3 umol/kg
For compound 4 the middle estimate is 1.0-fold (0.01 log units) below the measured one, within the range that was stated.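

In this assay, methyl in place of hydrogen on a saturated ring carbon gives a 1.4-fold lower number from compound 3 to compound 4 (0.16 log units; within the scatter), so these two compounds cannot be told apart. Set beside the earlier pair, the change gives the same result on both cores, and no difference between the two steps can be read: the same change on two cores in this assay, a 1.5-fold lower number (0.19 log units; within the scatter) from compound 1 to compound 2 and a 1.4-fold lower number (0.16 log units; within the scatter) from compound 3 to compound 4, 1.1-fold (0.03 log units) apart, within the scatter of two such steps

This shows that, on these two cores, the change can be carried across without a shift that stands out from the scatter of the measurements, but it does not show that methyl improves the effect, since neither step taken alone can be read as a real change, and two pairs say nothing about any further core.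

The compounds shown leave open what a group other than methyl would do on the same ring carbon, such as ethyl, hydroxyl or an amine. They also leave open whether the same quiet result would hold on a core with a longer chain than those of compound 1 and compound 3.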